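A few compounds are considered here, and "the series" means these few. Any claim that something is new, unique, unknown or untested is made for them only; others in the source may bear on it.

Measured compounds in the series:
compound 1, `COc1cc(-c2nnc3n2NC(c2ccco2)C(C(=O)c2ccccc2C)S3)cc(OC)c1OC`, 80000 nM
compound 2, `COc1cc(-c2nnc3n2NC(c2ccco2)C(C(=O)c2ccc(Cl)cc2)S3)cc(OC)c1OC`, 51400 nM
compound 3, `COc1cc(-c2nnc3n2NC(c2ccco2)C(C(=O)c2ccccc2)S3)cc(OC)c1OC`, 33400 nM

In a functional assay on A549 cells (Homo sapiens) for cytotoxicity, read by MTT assay, with a stated time of 48 h (on this read-out higher numbers stand for weaker inhibition and lower numbers for stronger inhibition), compound 3 gives the lowest of the three numbers. Its nearest neighbour is compound 2, and the step of a 1.5-fold lower number from compound 2 to compound 3 (0.19 log units; within the scatter) is within the scatter, so the two cannot be ordered. The step of a 2.4-fold lower number from compound 1 to compound 3 (0.38 log units; beyond the scatter) is beyond the scatter, so compound 3 stands apart from compound 1 alone.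

Compound 4, `COc1cc(-c2nnc3n2NC(c2ccco2)C(C(=O)c2ccc(C(F)(F)F)cc2)S3)cc(OC)c1OC`, differs from compound 3 by trifluoromethyl in place of hydrogen on an aromatic carbon. The change sits on the same six-membered aromatic ring of carbon only as the two earlier changes, para to a large group. Going by the values given here, the steps that bear on it are a 1.5-fold lower number from compound 2 to compound 3 (0.19 log units; within the scatter), within the scatter, and a 2.4-fold lower number from compound 1 to compound 3 (0.38 log units; beyond the scatter), modest; both ran toward a lower number when a substituent on this ring was removed, so putting a substituent back in is expected to run the other way, by a small amount, possibly within the scatter. The step of a 1.5-fold higher number from compound 3 to compound 4 (0.18 log units; within the scatter) is the expected size. Compound 4 is therefore estimated at 50000 nM, with a range from 20000 nM to 120000 nM.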

Compound 4, half-maximal inhibitory concentration: 37200 nM
Compound 4: middle estimate off by 1.3-fold (0.13 log units), on the high side; the measured number falls inside the stated range.
By their numbers in this assay, from the lowest: compounds 3, 4, 2 and 1 (each within the scatter of the next, the first and the last beyond it).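

In this assay, neither the step of a 1.1-fold higher number from compound 3 to compound 4 (0.05 log units; within the scatter) nor the step of a 1.4-fold lower number from compound 2 to compound 4 (0.14 log units; within the scatter) separates the compounds, so at this aromatic carbon hydrogen, chloro and trifluoromethyl cannot be ordered. The step of a 2.2-fold lower number from compound 1 to compound 4 (0.33 log units; beyond the scatter) adds 4-(trifluoromethyl)phenyl to phenyl as a second group that stands apart from the 2-methylphenyl of compound 1, although compound 2 remains within the scatter of compound 1 and so goes against any general split between that group and the others. No measurement here offers an explanation for these results.

On these data alone, whether an amine, a carboxylic acid or a longer chain on this aromatic carbon would give a step beyond the scatter remains open. As far as these compounds go, it is also open whether the separation of compound 1 follows from the methyl group itself or from where it sits on the ring.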